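Fluoro substitution on the aromatic ring of compound 2

The source may hold more compounds than are shown below. What is called first, only, known or untested is meant among the compounds shown, and "the series" means these compounds.

Measured so far:
- compound 1 `NC1=NCC(CC2=Cc3ccccc3CC2)O1`: 1000 nM
- compound 2 `C1=NCC(CC2Cc3ccccc3C2)N1`: 39.8 nM

In a functional assay for binding affinity to Norepinephrine transporter (Rattus norvegicus), read by radioligand binding, in the presence of a further agent that is not named here (on this read-out higher numbers stand for weaker inhibition and lower numbers for stronger inhibition), compound 1 gives 1000 nM. Compound 2 gives 39.8 nM in this assay, the lower of the two numbers; the gap to compound 1 lies beyond the usual scatter, so compound 2 stands as the stronger inhibitor of the pair. The two compounds differ in more than one place, so no single change can be read from that gap.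

Compound 3 `Fc1cccc2c1CC(CC1CN=CN1)C2` is not yet measured. It differs from compound 2 by fluoro in place of hydrogen on an aromatic carbon. Going by the values given here, no pair of measured compounds shows this change, so nothing tells its size or direction. The expectation is that the step from compound 2 to compound 3 in this assay stays within the scatter, a 1.0-fold higher number from compound 2 to compound 3 (0.00 log units; within the scatter), with no clear direction. Compound 3 is estimated at 40 nM in this assay, within a range of 15 nM to 120 nM.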

Compound 3, inhibition constant: 100 nM
Estimate against measurement, compound 3: 2.5-fold (0.40 log units) below, within the range that was stated.
By their numbers in this assay, from the lowest: compound 2; then compound 3; then compound 1.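

In this assay, going by these compounds alone, fluoro in place of hydrogen on an aromatic carbon, ortho to a fused ring, gives a 2.5-fold higher number from compound 2 to compound 3 (0.40 log units; beyond the scatter), and this is the first change that can be read at a single place. The earlier pair differed in more than one place and said nothing about the aromatic ring, whereas this step shows that the position is not indifferent to substitution: one fluoro atom moves the number modestly but beyond the scatter, towards weaker inhibition. No measurement shown here offers an explanation for the step, so it stands as an observation only.

The compounds shown carry fluoro at one place only, and it stays open whether the step belongs to this position or would appear with fluoro on any other aromatic carbon of the ring. Also open, on these data alone, are how a chloro or methoxy group would read at the same place, and whether fluoro would give a step of like size and direction on the core of compound 1.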